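The source may hold more compounds than are shown below. What is called first, only, known or untested is meant among the compounds shown, and "the series" means these compounds.

Compounds measured so far:
- compound 1, `Cc1cc(Nc2cc(-c3ccccc3)[nH]n2)n2nc(SCc3ccc([N+](=O)[O-])cc3)nc2n1`, gives 5060 nM in a functional assay on MCF7 cells (Homo sapiens) for inhibition, read by MTT assay, with a stated time of 72 h; a lower number here means a stronger inhibitor, a higher number a weaker inhibitor
- compound 2, `Cc1cc(Nc2cc(-c3ccccc3)[nH]n2)n2nc(SCc3ccc(Br)cc3)nc2n1`, gives 2720 nM in this assay

Both compounds share one core and differ only in the group on the aromatic ring at the end of the sulfur-linked chain. For the measured compounds named here, the single step recorded, a 1.9-fold lower number from compound 1 to compound 2 (0.27 log units; within the scatter), lies within the scatter, so compound 2 stands beside compound 1 with no separation the measurement can vouch for.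

Compound 3, `C=CCSc1nc2nc(C)cc(Nc3cc(-c4ccccc4)[nH]n3)n2n1`, is not yet measured. The change from compound 2 is vinyl in place of 4-bromophenyl on a saturated chain carbon bound to a sulfur. Here the whole aromatic ring leaves and a short chain with one double bond enters, so the bromine-for-nitro step is the only comparison available and it speaks to the ring's substituent, not to the ring itself. That step was within the scatter, which gives no sign that this end of the molecule is sensitive, but the loss of the ring is a larger change than anything measured.

The number for compound 3 is therefore expected to stay near the measured pair, with a wide range and a step of a 1.7-fold higher number from compound 2 to compound 3 (0.22 log units; within the scatter) that may well fall inside the scatter. The estimate for compound 3 in this assay is 4500 nM, between 1500 nM and 15000 nM.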

Compound 3, half-maximal inhibitory concentration: > 50000 nM
Compound 3 gave a limit, no number (the forecaster's own chance of this, stated with the estimate: 15%); middle value at least 11-fold (1.04 log units) from the limit.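

In this assay, compound 3 gives only a limit of the assay, not a number: the limit of > 50000 nM in this assay, at which 1 of the 3 values shown sits.

Replacing the ring at the end of the sulfur-linked chain with a short unsaturated group has a clear effect, with an at least 18-fold higher number from compound 2 to compound 3 (1.26 log units; beyond the scatter) for vinyl in place of 4-bromophenyl and an at least 9.8-fold higher number from compound 1 to compound 3 (0.99 log units; beyond the scatter) for vinyl in place of 4-nitrophenyl, both beyond the scatter. The earlier step, a 1.9-fold lower number from compound 1 to compound 2 (0.27 log units; within the scatter), changed only the group on that ring and could not reveal this, so among these three compounds, the presence of the aromatic ring at this position separates the measured inhibitors from the compound at the limit, while the choice between bromo and nitro does not.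

The compounds shown cannot say whether the aromatic ring itself matters or whether any group larger than allyl would serve, and a cyclohexyl ring or a longer chain such as hexyl in place of the vinyl would help to separate those two readings. They also leave open what an unsubstituted phenyl ring, or an amine or a carboxylic acid on that ring, would do at this position.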